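Hydroxypyrrolidine in Place of the Hydroxypentyl Chain

This account rests on a few compounds, and the source may have more. Where it says the series, first, only, none or still open, it means among the compounds named here.

Compound 2 `CC(C)(N)C(=O)N[C@H](COCc1ccccc1)c1nnnn1CCOC(=O)NCCCCCO` gives 14.6 nM in a functional assay on H4 cells with growth hormone secretagogue receptor type 1 (Homo sapiens) as the target, read by FLIPR (on this read-out lower numbers stand for an effect already at smaller amounts and higher numbers for an effect only at larger amounts of compound), the highest of the three numbers measured. Compound 1 `CC(C)(N)C(=O)N[C@H](COCc1ccccc1)c1nnnn1CCOC(=O)NCCCO` gives 5.5 nM, and compound 3 `CN(CCCCO)C(=O)OCCn1nnnc1[C@@H](COCc1ccccc1)NC(=O)C(C)(C)N` gives 3.8 nM. The chain extension a 2.7-fold higher number from compound 1 to compound 2 (0.42 log units; beyond the scatter) raised the number, while the shortened, methylated tail a 3.8-fold lower number from compound 2 to compound 3 (0.58 log units; beyond the scatter) lowered it; the step of a 1.4-fold lower number from compound 1 to compound 3 (0.16 log units; within the scatter) stays within the scatter. Compound 4 `CC(C)(N)C(=O)N[C@H](COCc1ccccc1)c1nnnn1CCOC(=O)N1CC[C@@H](O)C1` carries the change (3-hydroxypyrrolidin-1-yl in place of (5-hydroxypentyl)amino on a carbonyl carbon). Both measured steps from compound 2 suggest that drawing the hydroxyl closer to the nitrogen in this assay gives a lower number, so a modest step of a 2.4-fold lower number from compound 2 to compound 4 (0.39 log units; beyond the scatter) is expected for compound 4. Compound 4 is therefore estimated at 6 nM, with a range from 2.5 nM to 15 nM.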

Compound 4, half-maximal effective concentration: 1 nM
Beside the measured number, compound 4's estimate is 6.0-fold (0.78 log units) above it; measured number below the stated range.
By their numbers in this assay, from the lowest: compound 4; then compounds 3 and 1 (each within the scatter of the next); then compound 2.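

Placing 3-hydroxypyrrolidin-1-yl on the carbonyl carbon gave the first ring at this position and the largest step so far in this assay (a 15-fold lower number from compound 2 to compound 4 (1.16 log units; beyond the scatter)). The open-chain tails of the other compounds also lie above it (a 5.5-fold lower number from compound 1 to compound 4 (0.74 log units; beyond the scatter); a 3.8-fold lower number from compound 3 to compound 4 (0.58 log units; beyond the scatter)), so this position tolerates a ring and compound 4 has the lowest number of the four.

Still open, on these data alone, is how a plain pyrrolidin-1-yl, a 4-hydroxypiperidin-1-yl or the opposite configuration at the stereocentre would read out. Nothing available here explains the size of this gain.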